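This account rests on a few compounds, and the source may have more. Where it says the series, first, only, none or still open, it means among the compounds named here.

Measured in a functional assay on A549 cells (Homo sapiens) for antiproliferative activity, read by MTT assay, with a stated time of 48 h; a lower number here means a stronger inhibitor, a higher number a weaker inhibitor:
- Compound 1 `Cn1cc(C2=C(c3nn(CCCn4cncn4)c4ncccc34)C(=O)N(c3ccccc3)C2=O)c2ccccc21`: > 100000 nM (a limit of the assay, not a number)
- Compound 2 `Cn1cc(C2=C(c3nn(CCCn4ccnc4)c4ncccc34)C(=O)N(c3ccccc3)C2=O)c2ccccc21`: 1560 nM

Going by the values given here, compound 2 holds the only true number so far. Compound 3 `CN(C)CCCn1nc(C2=C(c3cn(C)c4ccccc34)C(=O)N(c3ccccc3)C2=O)c2cccnc21` changes it once more, with dimethylamino in place of 1H-imidazol-1-yl on the same chain: dimethylamino in place of 1H-imidazol-1-yl on a saturated chain carbon, three bonds along the chain from an aromatic nitrogen. Among the compounds with values here, the sole measured step, an at least 64-fold lower number from compound 1 to compound 2 (1.80 log units; beyond the scatter), is large and lies at this same place, so the number here can clearly move far. It gives no direction for the new group, however. A wide a 1.3-fold lower number from compound 2 to compound 3 (0.11 log units; within the scatter) is therefore expected, centred within the scatter. For compound 3 the estimate is 1200 nM, with an expected range of 200 nM to 8000 nM.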

Compound 3, half-maximal inhibitory concentration: 13000 nM
Compound 3: the middle estimate sits 11-fold (1.03 log units) below what was measured; the whole stated range lies below it.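

In this assay, the change to dimethylamino gives an 8.3-fold higher number from compound 2 to compound 3 (0.92 log units; beyond the scatter), so this position moves the number upward as well as downward, and compound 2 remains the strongest of the three. Dimethylamino, which has no ring, also gives an at least 7.6-fold lower number from compound 1 to compound 3 (0.88 log units; beyond the scatter), placing compound 3 between the two azole compounds. That step is only a bound, since compound 1 carries a limit of the assay rather than a number: the limit of > 100000 nM in this assay, at which 1 of the 3 values shown sits.

Still open, on these data alone, is how a morpholine or piperidine would fare at this position. As far as these compounds go, the effect of a shorter or longer chain carrying the imidazole also remains unknown.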